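The source may hold more compounds than are shown below. What is called first, only, known or untested is meant among the compounds shown, and "the series" means these compounds.

Of the compounds shown here, three sharing one core have been read in a functional assay on MCF7 cells (Homo sapiens) for inhibition, read by MTT assay, with a stated time of 72 h (on this read-out lower numbers stand for stronger inhibition and higher numbers for weaker inhibition), and they differ only in the group on a saturated chain carbon bound to a sulfur. Compound 1 `Cc1cc(Nc2cc(-c3ccccc3)[nH]n2)n2nc(SCc3c(Cl)cccc3Cl)nc2n1`, with 2,6-dichlorophenyl there, gives 3230 nM. Compound 2 `Cc1cc(Nc2cc(-c3ccccc3)[nH]n2)n2nc(SCc3ccc([N+](=O)[O-])cc3)nc2n1`, with 4-nitrophenyl, gives 5060 nM. Compound 3 `C=CCSc1nc2nc(C)cc(Nc3cc(-c4ccccc4)[nH]n3)n2n1`, with vinyl, gives > 50000 nM, which is a limit of the assay and not a number.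

Compound 4 `COc1ccc(CSc2nc3nc(C)cc(Nc4cc(-c5ccccc5)[nH]n4)n3n2)cc1` has yet to be measured. The change leading to it from compound 3 is 4-methoxyphenyl in place of vinyl on a saturated chain carbon bound to a sulfur.

Within the data shown here, three measured steps bear on this. Exchanging the two aromatic groups gave a 1.6-fold higher number from compound 1 to compound 2 (0.19 log units; within the scatter). Putting vinyl in place of 2,6-dichlorophenyl gave an at least 15-fold higher number from compound 1 to compound 3 (1.18 log units; beyond the scatter), and putting vinyl in place of 4-nitrophenyl gave an at least 9.8-fold higher number from compound 2 to compound 3 (0.99 log units; beyond the scatter). Both vinyl steps run against the limit, so their true sizes are open. Among the measured compounds shown here, only two aromatic groups have been seen, but compound 4 is expected to read like compound 1 and compound 2, which means a step of at least modest size toward a lower number in this assay. The expected step is an at least 8.3-fold lower number from compound 3 to compound 4 (0.92 log units; beyond the scatter). Compound 4 is estimated at 6000 nM, with an expected range from 2000 nM to 20000 nM.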

Compound 4, half-maximal inhibitory concentration: 4020 nM
Compound 4: middle estimate off by 1.5-fold (0.17 log units), on the high side, and the stated range covers the measured number.
By their numbers in this assay, from the lowest: compounds 1, 4 and 2 (each within the scatter of the next). At a limit, above all of these: compound 3.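

In this assay, 4-methoxyphenyl in place of vinyl on a saturated chain carbon bound to a sulfur gives an at least 12-fold lower number from compound 3 to compound 4 (1.09 log units; beyond the scatter), so the gap to vinyl now rests on three aromatic groups and not on two. Methoxy in place of nitro on an aromatic carbon gives a 1.3-fold lower number from compound 2 to compound 4 (0.10 log units; within the scatter), and 4-methoxyphenyl in place of 2,6-dichlorophenyl gives a 1.2-fold higher number from compound 1 to compound 4 (0.10 log units; within the scatter), so these three differently substituted aromatic groups cannot be told apart at this place in this assay. The value of compound 3 is a limit and not a number, so the step to compound 4 has only a bound and no measured size: the limit of > 50000 nM in this assay, at which 1 of the 4 values shown sits.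

On these data alone, whether the aromatic ring itself is what matters stays open, as a group without one, such as cyclohexyl or a longer alkyl chain, could read like vinyl or like the aromatic groups. As far as these compounds go, it is also open whether an amine or a carboxylic acid on the aromatic ring would move the number beyond the scatter of these three compounds, in either direction.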